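The source may report more compounds than this note shows. Statements on the series, on what has been measured and on what is new or still open speak of the compounds shown alone.

Measured in an ADME assay on the whole organism (Mus musculus, strain CD1) for pharmacokinetics, read by LC-MS, with a stated time of 24 h, at a dose of 1 mg/kg by the intravenous route; a higher number here means faster removal of the compound, a lower number slower removal:
Compound 1 `O=C(O)Cn1nc(Cc2nc3cc(Cl)c(OCC(F)F)cc3[nH]2)c2ccccc2c1=O` gives 51.7 mL/min/kg
Compound 2 `O=C(O)Cn1nc(Cn2cc3cc(OCC4CC4)c(Cl)cc3n2)c2ccccc2c1=O` gives 5.67 mL/min/kg

Compound 1 stands highest of the two numbers, with compound 2 lower by a gap beyond the scatter. Compound 3 `O=C(O)Cn1nc(Cc2nc3cc(Cl)c(OCC4CC4)cc3[nH]2)c2ccccc2c1=O` is the next to be read. It departs from compound 1 by cyclopropyl in place of difluoromethyl on a saturated chain carbon bound to an oxygen on an aromatic ring, which is 2,2-difluoroethoxy to cyclopropylmethoxy on the core of compound 1.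

Going by the values given here, no single-place step has been measured, so any expectation in this assay rests on thin ground. Among the compounds with values here, the only reading with cyclopropylmethoxy is compound 2 at 5.67 mL/min/kg, and that compound also differs elsewhere. A modest fall is therefore expected, estimated as a 1.7-fold lower number from compound 1 to compound 3 (0.24 log units; within the scatter) and not clearly beyond the scatter. Compound 3 is expected near 30 mL/min/kg, within an estimated range of 12 mL/min/kg to 70 mL/min/kg in this assay.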

Compound 3, clearance in the Mus musculus assay: 18.3 mL/min/kg
Compound 3: the middle estimate sits 1.6-fold (0.21 log units) above what was measured; low and high end bracket the measured number.
By their numbers in the Mus musculus assay, from the lowest: compound 2; then compound 3; then compound 1.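

Going by these compounds alone, in the Mus musculus assay, the only single-place step shows that this position bears on the read-out: cyclopropyl in place of difluoromethyl on a saturated chain carbon bound to an oxygen on an aromatic ring gives a 2.8-fold lower number from compound 1 to compound 3 (0.45 log units; beyond the scatter). In a physicochemical assay for solubility, measured as thermodynamic solubility, at pH 7.4 (a higher number here means a more soluble compound, a lower number a less soluble compound), the same change gives an at least 2.5-fold lower number from compound 1 to compound 3 (0.40 log units; beyond the scatter). In the physicochemical assay compound 3 gives 395 ug/mL. In the physicochemical assay compound 1 gives > 1000 ug/mL, which is a limit of the assay and not a number: the limit of > 1000 ug/mL in the physicochemical assay, at which 1 of the 2 values shown sits.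

The compounds shown hold only this one pair of groups at this place, so it stays open how a longer chain, a trifluoromethyl end group or an amine would read in either assay. From the compounds shown here alone, the true size of the step in the physicochemical assay also stays open, as does whether the step in the Mus musculus assay carries over to the core of compound 2.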